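A few compounds are considered here, and "the series" means these few. Any claim that something is new, unique, unknown or untested is made for them only; others in the source may bear on it.

Three compounds from one series, all sharing the core seen in compound 1 `COc1cc(-c2nn(-c3cccc(NC(=O)c4cccc(C(F)(F)F)c4)c3)cc2-c2ccncc2)ccc1Cl`, have been tested in a functional assay on KM12 cells (Homo sapiens) for inhibition, read by sulforhodamine B assay, with a stated time of 48 h; a lower number here means a stronger inhibitor of growth, a higher number a weaker inhibitor of growth. Compound 1 carries a trifluoromethylphenyl on the carbonyl carbon and reaches only the limit of the assay, giving > 50000 nM. Compound 2 `COc1cc(-c2nn(-c3cccc(NC(=O)Nc4cccc(C(F)(F)F)c4)c3)cc2-c2ccncc2)ccc1Cl` instead carries a (3-(trifluoromethyl)phenyl)amino there and gives 1980 nM. Compound 3 `COc1cc(-c2nn(-c3cccc(NC(=O)Nc4ccc(Cl)c(C(F)(F)F)c4)c3)cc2-c2ccncc2)ccc1Cl` carries a (4-chloro-3-(trifluoromethyl)phenyl)amino and gives 3920 nM; among the two real numbers it is the higher one, though the step between them is small: a 2.0-fold higher number from compound 2 to compound 3 (0.30 log units; within the scatter). Against the limit of compound 1 the steps were large: an at least 25-fold lower number from compound 1 to compound 2 (1.40 log units; beyond the scatter) and an at least 12-fold lower number from compound 1 to compound 3 (1.10 log units; beyond the scatter), with the limit itself being the only evidence on them (the limit of > 50000 nM in this assay, at which 1 of the 3 values shown sits).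

Compound 4 `COc1cc(-c2nn(-c3cccc(NC(=O)c4ccccc4)c3)cc2-c2ccncc2)ccc1Cl` has not been measured. It differs from compound 3 in that (phenyl in place of (4-chloro-3-(trifluoromethyl)phenyl)amino on a carbonyl carbon). This change undoes the move that produced the large step from compound 1 to compound 3, and removes the chloro and trifluoromethyl as well, so compound 4 is expected to sit near the limit of compound 1. The expected step is therefore a 15-fold higher number from compound 3 to compound 4 (1.18 log units; beyond the scatter), upward, and compound 4 is estimated at 60000 nM, between 10000 nM and 300000 nM, with a real chance that only a limit is reported.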

Compound 4, concentration for total growth inhibition: > 100000 nM
Compound 4: no number, only a limit (the forecaster's own chance of this, stated with the estimate: 70%); at least 1.6-fold (0.22 log units) between middle value and limit.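

On the carbonyl carbon, phenyl in place of either arylamino group costs a large step, an at least 25-fold higher number from compound 3 to compound 4 (1.40 log units; beyond the scatter) and an at least 50-fold higher number from compound 2 to compound 4 (1.70 log units; beyond the scatter), so the gain seen earlier with the trifluoromethyl-bearing ring now also holds against the bare phenyl. In this assay compound 4 gives > 100000 nM, which is a limit and not a number, so both of these steps are minimum sizes: the limit of > 100000 nM in this assay, at which 1 of the 4 values shown sits. Among the four compounds shown, only those with an amino nitrogen on the carbonyl carbon give real numbers, with no exception, while the step from compound 1 to compound 4 cannot be read, so removing trifluoromethyl from the phenyl shows no readable effect: the limit of > 50000 nM in this assay, at which 1 of the 4 values shown sits.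

The compounds shown leave open whether plain phenylamino on the carbonyl carbon, with neither chloro nor trifluoromethyl, would still give a real number in this assay, which would tell how far the amino nitrogen suffices without those ring groups. Also open, going by these compounds, is how a benzylamino group, a cyclohexylamino group or a longer chain on that carbon would read.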